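Trifluoromethyl in Place of Difluoro on the Amide

A few compounds are considered here, and "the series" means these few. Any claim that something is new, unique, unknown or untested is made for them only; others in the source may bear on it.

Of the compounds shown here, two have so far been measured in a functional assay on HEK293 cells for antagonist activity at melanin-concentrating hormone receptor 1 (Homo sapiens), read by FLIPR and calcium flux; on this read-out higher numbers stand for weaker inhibition and lower numbers for stronger inhibition. Compound 1 `Cc1cc(N(C)C)nc(N[C@H]2CC[C@@H](NC(=O)c3ccc(F)c(F)c3)CC2)n1` gives 2.5 nM. Compound 2 `Cc1cnc(N[C@H]2CC[C@@H](CNC(=O)c3ccc(F)c(F)c3)CC2)nc1N(C)C` gives 120 nM, the higher of the two numbers; its gap to compound 1 lies beyond the scatter, so compound 2 is the weaker inhibitor of the pair. Compound 3 `Cc1cnc(N[C@H]2CC[C@@H](CNC(=O)c3cccc(C(F)(F)F)c3)CC2)nc1N(C)C` has not yet been measured. It differs from compound 2 in a single place: 3-(trifluoromethyl)phenyl in place of 3,4-difluorophenyl on a carbonyl carbon. The shared core and the amide linkage stay the same. Among the compounds with values here, no measured pair shows what this particular exchange does to the read-out, so the expectation rests on compound 2 alone, without a guide for direction. Across this exchange the expected step is a 1.3-fold higher number from compound 2 to compound 3 (0.10 log units; within the scatter), small and with no clear direction beyond the scatter. Compound 3 is therefore estimated at 150 nM, within a range from 40 nM to 600 nM.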

Compound 3, half-maximal inhibitory concentration: 26 nM
The estimate for compound 3 lay 5.8-fold (0.76 log units) above the measured number; the measured number lies below the stated range.
By their numbers in this assay, from the lowest: compound 1; then compound 3; then compound 2.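

The aryl group on the amide carbonyl is not a silent position: in this assay, 3-(trifluoromethyl)phenyl in place of 3,4-difluorophenyl gives a 4.6-fold lower number from compound 2 to compound 3 (0.66 log units; beyond the scatter) and so stronger inhibition. Within the data shown here, this is the first pair that differs in one place only, and it gives the first direct reading of what a change at this position can do to the number. Nothing measured here accounts for the gain.

The exchange swaps two fluorines for one trifluoromethyl group in a single step, so the compounds shown cannot say how much each part contributes; a plain phenyl, or a phenyl carrying a nitrile or a methoxy group, would help separate them. Going by these compounds, it also remains open whether the same exchange would lower the number on the core of compound 1.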